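Closing the Alkyne Amino Alcohol into a Pyrrolidine Ring

The source may hold more compounds than are shown below. What is called first, only, known or untested is meant among the compounds shown, and "the series" means these compounds.

Compound 1 `COc1cc[nH]c1/C=C1/C(=O)Nc2ccc(F)cc21` is the bare core of this set. In a functional assay on MDA-MB-435 cells (Homo sapiens) for inhibition (a lower number here means a stronger inhibitor, a higher number a weaker inhibitor), compound 1 reports only a limit, > 30000 nM (the limit of > 30000 nM in this assay, at which 1 of the 3 values shown sits). Compound 2 `COc1cc[nH]c1/C=C1\C(=O)Nc2ccc(F)c(C#C[C@H](C)O)c21` gives 190 nM in this assay. Compound 3 `CCN[C@H](C#Cc1c(F)ccc2c1/C(=C/c1[nH]ccc1OC)C(=O)N2)CO` gives 1160 nM in this assay, the higher of the two numbers recorded, with compound 2 its nearest neighbour; the change between them, 1-(ethylamino)-2-hydroxyethyl in place of 1-hydroxyethyl on a triple-bonded carbon, reads a 6.1-fold higher number from compound 2 to compound 3 (0.79 log units; beyond the scatter).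

Compound 4 `COc1cc[nH]c1/C=C1\C(=O)Nc2ccc(F)c(C#C[C@@H]3C[C@@H](O)CN3)c21` has not been measured. It differs from compound 3 only here: 4-hydroxypyrrolidin-2-yl in place of 1-(ethylamino)-2-hydroxyethyl on a triple-bonded carbon. For the measured compounds named here, the single measured step that touches the same triple-bonded carbon, from compound 2 to compound 3, was modest and went to a higher number when the amino alcohol chain was added. Closing that chain into a ring keeps the same counts of atoms, donors and acceptors, so only a modest move is expected, most likely back toward compound 2. Compound 4 is estimated at 500 nM in this assay, within 150 nM to 2000 nM, a step of a 2.3-fold lower number from compound 3 to compound 4 (0.37 log units; beyond the scatter) expected from compound 3.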

Compound 4, half-maximal inhibitory concentration: 63 nM
Compound 4: middle estimate off by 7.9-fold (0.90 log units), on the high side, outside the stated range (below it).
By their numbers in this assay, from the lowest: compound 4; then compound 2; then compound 3. At a limit, above all of these: compound 1.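

In this assay, putting 4-hydroxypyrrolidin-2-yl in place of 1-(ethylamino)-2-hydroxyethyl on this triple-bonded carbon gave an 18-fold lower number from compound 3 to compound 4 (1.27 log units; beyond the scatter), so the ring and the open chain are not interchangeable here, even though their heavy-atom and hydrogen-bond counts match. The ring also passes the smaller 1-hydroxyethyl group, with a 3.0-fold lower number from compound 2 to compound 4 (0.48 log units; beyond the scatter), so among these compounds a nitrogen-bearing group at this carbon does not always go with a higher number than 1-hydroxyethyl: compound 3 reads higher than compound 2, compound 4 lower. Nothing measured here bears on why the ring and the chain differ.

As far as these compounds go, what remains open is how a plain pyrrolidin-2-yl, a piperidine ring or an ethyl group on the ring nitrogen would compare with 4-hydroxypyrrolidin-2-yl. Also open, from the compounds shown here alone, is whether the other arrangements of its two stereocentres would give the same reading.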